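A few compounds are considered here, and "the series" means these few. Any claim that something is new, unique, unknown or untested is made for them only; others in the source may bear on it.

Compound 1 `C#Cc1cn([C@@H]2O[C@H](CO)[C@@H](O)[C@H]2O)c2ncnc(N(C)C)c12`: 290 nM in a functional assay on HCT-116 cells (Homo sapiens), read by MTT assay, with a stated time of 72 h; a higher number here means a weaker inhibitor, a lower number a stronger inhibitor.
Compound 2 `COc1ncnc2c1c(-c1cccs1)cn2[C@@H]1O[C@H](CO)[C@@H](O)[C@H]1O`: 440 nM in this assay.
Compound 3 `Cc1ncnc2c1c(-c1cccs1)cn2[C@@H]1O[C@H](CO)[C@@H](O)[C@H]1O`: > 20000 nM in this assay.

Compound 3 stands apart: its value is a limit of the assay and not a number, so only a floor of weakness is known for compound 3. That limit is the one at which a single value sits (the limit of > 20000 nM in this assay, at which 1 of the 3 values shown sits). Compound 4 `CN(C)c1ncnc2c1c(-c1cccs1)cn2[C@@H]1O[C@H](CO)[C@@H](O)[C@H]1O` differs from compound 3 in one place: dimethylamino in place of methyl on an aromatic carbon. For the measured compounds named here, the one measured step that bears on this is an at least 45-fold higher number from compound 2 to compound 3 (1.65 log units; beyond the scatter), where the methyl made the inhibitor much weaker. Compound 1 also carries a dimethylamino and in this assay compound 1 gives 290 nM. A large step toward stronger inhibition is therefore expected, an at least 57-fold lower number from compound 3 to compound 4 (1.75 log units; beyond the scatter). Compound 4 is estimated at 350 nM, with a range from 100 nM to 1500 nM.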

Compound 4, half-maximal inhibitory concentration: > 20000 nM
Compound 4 was reported as a limit; the forecaster's own chance of this, stated with the estimate: 5%; middle value at least 57-fold (1.75 log units) away from the limit.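

Compound 4 is a limit of the assay, as compound 3 is, so the step between those two cannot be read: the limit of > 20000 nM in this assay, at which 2 of the 4 values shown sit. For the compounds shown here, with thiophen-2-yl in the shared core, dimethylamino in place of methoxy gives an at least 45-fold higher number from compound 2 to compound 4 (1.65 log units; beyond the scatter) in this assay, so at this position methoxy is the only one of the three groups with a measured value. With dimethylamino kept, thiophen-2-yl in place of ethynyl gives an at least 68-fold higher number from compound 1 to compound 4 (1.83 log units; beyond the scatter), so dimethylamino does not suffice alone: the neighbouring group also counts. From the compounds shown here alone, whether an ethoxy or a primary amine here would match methoxy remains open.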